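Sulfone series: clearance notes toward compound 4

The source may report more compounds than this note shows. Statements on the series, on what has been measured and on what is new or still open speak of the compounds shown alone.

In an ADME assay on microsomes from liver (Homo sapiens) for metabolic stability, tested at 2.5 uM (a higher number here means faster removal of the compound, a lower number slower removal), compound 1 `O=S(=O)(c1cc(F)cc(F)c1)c1cnc2c(F)cccc2c1-c1ccccc1F` gives 0.09 mL/min, compound 2 `O=S(=O)(c1ccc(F)c(Cl)c1)c1cnc2c(F)cccc2c1-c1ccccc1F` gives 1.39 mL/min and compound 3 `COc1cccc(-c2c(S(=O)(=O)c3cc(F)cc(F)c3)cnc3cc(F)ccc23)c1` gives 1.81 mL/min. Among the compounds with values here, compound 2 thus holds the second highest of the three numbers; compound 3 sits within the scatter of it, whereas compound 1 sits far lower, the single measured step being a 15-fold higher number from compound 1 to compound 2 (1.19 log units; beyond the scatter), a large one. Compound 4 `O=S(=O)(c1ccc(F)c(Cl)c1)c1cnc2c(F)cccc2c1-c1ccc(F)cc1` is not yet measured in this assay. It differs from compound 2 in one place: 4-fluorophenyl in place of 2-fluorophenyl on an aromatic carbon. The group that leaves and the group that enters have the same atoms, joined differently. Within the data shown here, the only measured step concerns the group on the sulfonyl sulfur, not the aromatic carbon altered here, so it offers no direct guide, and no measured pair varies the fluorophenyl on that carbon. Among the measured compounds shown here, with no precedent of that kind, the step from compound 2 to compound 4 is expected to stay within the scatter, a 1.0-fold higher number from compound 2 to compound 4 (0.00 log units; within the scatter). Compound 4 is therefore estimated at 1.4 mL/min, with a range of 0.6 mL/min to 3.2 mL/min in this assay.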

Compound 4, intrinsic clearance in a liver preparation (reported as CLH), per the amount of preparation that the assay uses: 0.19 mL/min
Compound 4: middle estimate off by 7.4-fold (0.87 log units), on the high side; measured number outside the range, below it.
By their numbers in this assay, from the lowest: compound 1; then compound 4; then compounds 2 and 3 (each within the scatter of the next).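

In this assay, 4-fluorophenyl in place of 2-fluorophenyl on the aromatic carbon opposite the ring nitrogen gives a 7.3-fold lower number from compound 2 to compound 4 (0.86 log units; beyond the scatter). The number at this position therefore responds to how the fluorophenyl is joined, even though the group that leaves and the group that enters have the same atoms and the same counts of donors and acceptors. Within the data shown here, until this pair, the only measured step lay on the sulfonyl sulfur, so this is the first sign that this aromatic carbon matters as well, and nothing at hand accounts for the shift.

From the compounds shown here alone, it remains open whether the same swap would give a step of similar size with 3,5-difluorophenyl on the sulfonyl sulfur. Also open, going by these compounds, is how an unsubstituted phenyl, or a phenyl carrying an amine, would read at this carbon.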